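This account rests on a few compounds, and the source may have more. Where it says the series, first, only, none or still open, it means among the compounds named here.

Measured compounds:
compound 1, `CC(C)CSc1nc(N)nc2c1ncn2/C=C1/CC1(CO)CO`, in an ADME assay on MOLT-3 cells (Homo sapiens) for cytotoxicity, with a stated time of 7 days (on this read-out lower numbers stand for higher toxicity in this test and higher numbers for lower toxicity in this test), gives "not determined" (no result reported);
compound 2, `COCCOc1nc(N)nc2c1ncn2/C=C1/CC1(CO)CO`, gives > 20000 nM;
compound 3, `Nc1nc(NC2CC2)c2ncn(/C=C3/CC3(CO)CO)c2n1`, gives > 20000 nM.

Three analogues share one core and differ in the group on one aromatic carbon. For compound 1 no result is recorded in this assay. Compound 2 reaches only a limit of the assay, > 20000 nM. Compound 3 likewise reaches only a limit, > 20000 nM. For the measured compounds named here, the single step between measured compounds, a step that the two limits leave unreadable from compound 2 to compound 3, therefore cannot be read, and the whole of the evidence is the limit of > 20000 nM in this assay, at which 2 of the 3 values shown sit.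

Compound 4, `CCCCNc1nc(N)nc2c1ncn2/C=C1/CC1(CO)CO`, remains to be measured. Its change from compound 3 is butyl in place of cyclopropyl on a nitrogen on an aromatic ring. Going by the values given here, no measured step touches this change: the one step recorded, from a 2-methoxyethoxy to a cyclopropylamino group, left both partners at the limit, and the step from cyclopropylamino to butylamino has no counterpart. With compound 3 at the limit, compound 4 is expected to stay there as well, a step that the limit leaves unreadable from compound 3 to compound 4. Compound 4 is therefore estimated at 30000 nM, within 10000 nM to 100000 nM.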

Compound 4, half-maximal cytotoxic concentration: > 20000 nM
Compound 4: no number, only a limit; the forecaster's own chance of this, stated with the estimate: 75%; the middle value lies beyond the limit too.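

Compound 4 gives > 20000 nM in this assay, which is a limit of the assay and not a number. For the compounds shown here, no step from compound 2 or compound 3 to compound 4 can therefore be read. The compounds shown leave open whether the butylamino, cyclopropylamino and 2-methoxyethoxy groups differ at all in cytotoxicity.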